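A few compounds are considered here, and "the series" means these few. Any claim that something is new, unique, unknown or untested is made for them only; others in the source may bear on it.

Of the compounds shown here, three sharing one core have been measured in an assay on HEK293 cells for inhibition of sodium-dependent dopamine transporter (Homo sapiens), read by scintillation counting, with stated times of 5 min and 1 min; a higher number here means a weaker inhibitor, a lower number a stronger inhibitor. Compound 1 `O=c1[nH]nc(C[S+]([O-])C(c2ccccc2)c2ccccc2)s1` gives 38100 nM. Compound 2 `[O-][S+](Cc1cc(Br)cs1)C(c1ccccc1)c1ccccc1` gives 13700 nM in this assay, the lowest of the three numbers and therefore the strongest inhibitor among them, since both of its steps to the others lie beyond the scatter. Compound 3 `Cc1cnc(C[S+]([O-])C(c2ccccc2)c2ccccc2)nc1` gives 156000 nM in this assay. The measured steps read: a 2.8-fold lower number from compound 1 to compound 2 (0.44 log units; beyond the scatter), a 4.1-fold higher number from compound 1 to compound 3 (0.61 log units; beyond the scatter) and an 11-fold higher number from compound 2 to compound 3 (1.06 log units; beyond the scatter). Every one of them is beyond the scatter, so the aromatic ring on the saturated chain carbon bound to a sulfur clearly shapes the result.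

Compound 4 `[O-][S+](Cc1ccsc1)C(c1ccccc1)c1ccccc1` has not yet been measured. It differs from compound 2 in one place: thiophen-3-yl in place of 4-bromothiophen-2-yl on a saturated chain carbon bound to a sulfur. The ring stays a thiophene, but the bromine is gone and the ring enters as thiophen-3-yl rather than as 4-bromothiophen-2-yl. For the measured compounds named here, no measured step covers exactly this change; the steps that bear on it, a 2.8-fold lower number from compound 1 to compound 2 (0.44 log units; beyond the scatter) and an 11-fold higher number from compound 2 to compound 3 (1.06 log units; beyond the scatter), show that exchanging this ring moves the number by modest to large amounts. Because compound 2 holds the lowest number at 13700 nM, and because the change removes the bromine that sets compound 2 apart, a modest rise is expected. Compound 4 is therefore estimated to give about 30000 nM in this assay, within a range of 10000 nM to 90000 nM. The expected step is a 2.2-fold higher number from compound 2 to compound 4 (0.34 log units; beyond the scatter).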

Compound 4, half-maximal inhibitory concentration: 3000 nM
Compound 4: the middle estimate sits 10-fold (1.00 log units) above what was measured; measured number outside the range, below it.
By their numbers in this assay, from the lowest: compound 4; then compound 2; then compound 1; then compound 3.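

In this assay, a 4.6-fold lower number from compound 2 to compound 4 (0.66 log units; beyond the scatter) shows that a low number at this position does not depend on the bromine, since the smaller thiophen-3-yl outdoes 4-bromothiophen-2-yl. Together with a 52-fold lower number from compound 3 to compound 4 (1.72 log units; beyond the scatter) and a 13-fold lower number from compound 1 to compound 4 (1.10 log units; beyond the scatter), this makes compound 4 the strongest inhibitor of the four and shows that the ring on the saturated chain carbon bound to a sulfur can move the number further than the earlier compounds revealed. No measurement here gives a reason for this gain.

As far as these compounds go, the change from compound 2 to compound 4 does two things at once, removing the bromine and altering how the thiophene enters, so the share of each stays open; a thiophene without bromine that enters as in compound 2, or a bromothiophene that enters as in compound 4, would separate them. Also open, from the compounds shown here alone, is how this position responds to a plain phenyl ring or to a longer chain ending in an amine.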